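Replacing 4-fluorophenyl with phenyl on a shared core

A few compounds are considered here, and "the series" means these few. Any claim that something is new, unique, unknown or untested is made for them only; others in the source may bear on it.

Compound 1 `CN1CCN(c2ccc(Nc3ncc4nc(Nc5ccccc5)n([C@H]5CCN(C(=O)OC(C)(C)C)C5)c4n3)cc2)CC1` gives "not determined" (no result reported) as its entry
Compound 2 `CN1CCN(c2ccc(Nc3ncc4nc(Nc5ccc(F)cc5)n([C@@H]5CCN(S(=O)(=O)C6CC6)C5)c4n3)cc2)CC1` gives > 10000 nM as a limit, not a number

In a functional assay on A-431 cells (Homo sapiens) for antiproliferative activity, read by MTT assay, with a stated time of 72 h (a lower number here means a stronger inhibitor, a higher number a weaker inhibitor), compound 2 gives > 10000 nM and this is a limit of the assay. Compound 1 has no result to compare with it. Compound 3 `CN1CCN(c2ccc(Nc3ncc4nc(Nc5ccccc5)n([C@@H]5CCN(S(=O)(=O)C6CC6)C5)c4n3)cc2)CC1` differs from compound 2 in one place, with hydrogen in place of fluoro on an aromatic carbon so that 4-fluorophenyl becomes phenyl. For the measured compounds named here, no measured pair shows this change, so no shift beyond the scatter is expected, in either direction. The expected size is a number no higher from compound 2 to compound 3 (the limit leaves the size open) as an estimate only. For compound 3 the expected value is 10000 nM within an estimated range of 3000 nM to 30000 nM. A limit alone may again be the outcome.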

Compound 3, half-maximal inhibitory concentration: > 10000 nM
Compound 3 ended at the assay's limit; the forecaster's own chance of this, stated with the estimate: 60%; the middle value sits exactly at the limit.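

For the compounds shown here, no step from compound 2 to compound 3 can be read, because both entries are limits rather than numbers: the limit of > 10000 nM in this assay, at which 2 of the 3 values shown sit.

Going by these compounds, whether hydrogen in place of fluoro changes activity at all remains open.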